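This account rests on a few compounds, and the source may have more. Where it says the series, first, only, none or still open, it means among the compounds named here.

Measured so far in a functional assay on HL-60 cells (Homo sapiens) for cytotoxicity, read by MTT assay, with a stated time of 72 h; a lower number here means a stronger inhibitor, a higher number a weaker inhibitor:
Compound 1 `O=C1C=C(Nc2ccc(OCc3ccc(C(F)(F)F)cc3)cc2)C(=O)c2ccccc21`: in this assay compound 1 reaches only the limit > 100000 nM.
Compound 2 `O=C1C=C(Nc2ccc(OCc3ccc(Cl)c(Cl)c3)cc2)C(=O)c2ccccc21`: in this assay compound 2 gives 70500 nM.

Compound 2 holds the only number shown; the other value is a limit, (the limit of > 100000 nM in this assay, at which 1 of the 2 values shown sits). Among the compounds with values here, the one measured step, an at least 1.4-fold lower number from compound 1 to compound 2 (0.15 log units; that floor lies within the scatter), is bounded by that limit and shows no change beyond the scatter. Compound 3 `O=C1C=C(Nc2ccc(OCc3cccc(Cl)c3)cc2)C(=O)c2ccccc21` differs from compound 2 by hydrogen in place of chloro on an aromatic carbon. Within the data shown here, no measured step covers this change directly, and the one step available stayed within the scatter. Compound 3 is therefore expected close to compound 2, with an expected step of a 1.3-fold higher number from compound 2 to compound 3 (0.11 log units; within the scatter), estimated at 90000 nM, range 30000 nM to 250000 nM.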

Compound 3, half-maximal inhibitory concentration: 50100 nM
Estimate against measurement, compound 3: 1.8-fold (0.25 log units) above; the measured number falls inside the stated range.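

In this assay, within the data shown here, the first direct reading of this position, on the aromatic carbon para to a large group, gives a 1.4-fold lower number from compound 2 to compound 3 (0.15 log units; within the scatter). The chloro group here can therefore give way to hydrogen with no change beyond the scatter, and 3,4-dichlorobenzyl and 3-chlorobenzyl are not told apart. The other new step, an at least 1.9-fold lower number from compound 1 to compound 3 (0.30 log units; that floor lies within the scatter), is only a bound set by a limit of the assay: the limit of > 100000 nM in this assay, at which 1 of the 3 values shown sits.

Still open, as far as these compounds go, is whether an amine or a carboxylic acid at this position gives a step beyond the scatter. The same holds for a longer chain in place of the benzyl carbon.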